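This account rests on a few compounds, and the source may have more. Where it says the series, first, only, none or still open, it means among the compounds named here.

Measured so far in an assay on isolated protein for binding affinity to Leucine-rich repeat serine/threonine-protein kinase 2 variant G2019S (Homo sapiens), read by TR-FRET and LanthaScreen, with a stated time of 2 h; a higher number here means a weaker inhibitor, a lower number a stronger inhibitor:
- compound 1, `C[C@@H]1CCCN1c1c(C#N)c2c(N)nc(Nc3ccn(C)n3)cc2n1C`: 13 nM
- compound 2, `Cc1nn(C)cc1Nc1nc(N)c2c(C#N)c(N3CCC[C@H]3C)n(C)c2n1`: 2 nM
- compound 3, `Cn1c(-n2cccc2)c(C#N)c2c(N)ncnc21`: 1980 nM

Compound 1 sits second highest of the three numbers. Its nearest neighbour is compound 2, whose number is lower by a margin beyond the scatter; the furthest is compound 3, whose number is far higher, again well beyond the scatter. The two compounds with the larger pyrrolidine-bearing core, compound 1 and compound 2, both give low numbers, while compound 3, which carries a pyrrol-1-yl group in that place and no amine-linked substituent, gives a far higher number. Among the compounds with values here, no step between two measured compounds that differ in a single place has been recorded, so the effect of any one change has not been isolated.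

Compound 4, `C[C@@H]1CCCN1c1c(C#N)c2c(N)nc(Nc3cnn(C)c3)cc2n1C`, is not yet measured. It differs from compound 1 in one place: 1-methyl-1H-pyrazol-4-yl in place of 1-methyl-1H-pyrazol-3-yl on a nitrogen on an aromatic ring. The change moves the point of attachment of the same six-atom ring without altering its atom count, donor or acceptor count, or charge.

Within the data shown here, no measured step covers this change. Given that compound 2 gives 2 nM in this assay, the expectation is a step from compound 1 to compound 4 of a 1.9-fold lower number from compound 1 to compound 4 (0.27 log units; within the scatter), downward, at or just beyond the edge of the scatter. Compound 4 is estimated at 7 nM, with a range from 2.5 nM to 20 nM.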

Compound 4, inhibition constant: 794 nM
Estimate against measurement, compound 4: 110-fold (2.05 log units) below; measured number above the stated range.
By their numbers in this assay, from the lowest: compound 2; then compound 1; then compound 4; then compound 3.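

In this assay, within the data shown here, the point of attachment of the 1-methyl-1H-pyrazole ring on the amino nitrogen proves decisive: 1-methyl-1H-pyrazol-4-yl in place of 1-methyl-1H-pyrazol-3-yl gives a 61-fold higher number from compound 1 to compound 4 (1.79 log units; beyond the scatter), the first single-place step and a large one. The two groups match in heavy atoms, hetero atoms, hydrogen-bond donors, hydrogen-bond acceptors and net charge, so this position responds to how the same ring is joined, a difference that none of those counts captures. No measurement at hand bears on what lies behind the step.

Open, as far as these compounds go, is whether the 1-methyl-1H-pyrazol-3-yl group is itself close to the best choice on this nitrogen, or whether a pyridin-2-yl, a phenyl or a 1-ethyl-1H-pyrazol-3-yl would match or pass it. Also open, from the compounds shown here alone, is whether the same exchange of attachment point costs as much on other cores, since this single step rests on the core of compound 1 alone.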